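A few compounds are considered here, and "the series" means these few. Any claim that something is new, unique, unknown or untested is made for them only; others in the source may bear on it.

Measured compounds:
- compound 1 `Nc1n/c(=N\CCCCc2ccccc2)nc(N)c2c1ncn2Cc1ccccc1`: > 75000 nM
- compound 2 `CCCCCCCC/N=c1\nc(N)c2ncn(Cc3ccccc3)c2c(N)n1`: 5930 nM
- compound 3 `CCCCCCCC/N=c1\nc(N)c2ncn(Cc3ccc(OC)cc3)c2c(N)n1`: 5900 nM

All three share one core and are tested in a functional assay on PC-3 cells (Homo sapiens) for antiproliferative activity, read by WST assay, with a stated time of 72 h; on this read-out higher numbers stand for weaker inhibition and lower numbers for stronger inhibition. For compound 1 the result is a limit of the assay, > 75000 nM, not a number. Compound 2 gives 5930 nM, and the step of an at least 12-fold lower number from compound 1 to compound 2 (1.10 log units; beyond the scatter). Compound 3 gives 5900 nM, which is the lowest of the two numbers shown, although the step of a 1.0-fold lower number from compound 2 to compound 3 (0.00 log units; within the scatter), so compound 2 and compound 3 cannot be told apart.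

Compound 4 `CCCCCCCC/N=c1\nc(N)c2ncn(Cc3ccc(F)cc3)c2c(N)n1` is not yet measured. Compared with compound 3 the change is fluoro in place of methoxy on an aromatic carbon. Among the measured compounds shown here, the only step that bears on this position is the one in which a methoxy entered the same aromatic carbon, a 1.0-fold lower number from compound 2 to compound 3 (0.00 log units; within the scatter); changing that group again is therefore expected to leave this assay essentially unchanged. For compound 4 the expected step is a 1.0-fold higher number from compound 3 to compound 4 (0.01 log units; within the scatter), and compound 4 is estimated at 6000 nM, within a range from 2500 nM to 15000 nM.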

Compound 4, half-maximal inhibitory concentration: 3800 nM
Compound 4: the middle estimate sits 1.6-fold (0.20 log units) above what was measured; the measured number falls inside the stated range.
By their numbers in this assay, from the lowest: compounds 4, 3 and 2 (each within the scatter of the next). At a limit, above all of these: compound 1.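

Fluoro in place of methoxy gives a 1.6-fold lower number from compound 3 to compound 4 (0.19 log units; within the scatter) in this assay and fluoro in place of hydrogen gives a 1.6-fold lower number from compound 2 to compound 4 (0.19 log units; within the scatter) in the same read-out, so neither step can be read as a real difference. Until now, this aromatic carbon had been tested only with hydrogen and methoxy; with fluoro as a third group, the 4-fluorobenzyl, 4-methoxybenzyl and plain benzyl compounds still cannot be told apart here, and none of the three groups stands out. The data shown offer no explanation for this lack of a readable difference.

As far as these compounds go, whether an amine or a carboxylic acid on this same aromatic carbon would move the number beyond the scatter remains open. Also open, from the compounds shown here alone, is whether a longer chain on the double-bonded nitrogen would change the result for compound 4.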